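Exchanging a Dimethylphenyl for a Hydroxyphenyl on the Side Chain

The source may report more compounds than this note shows. Statements on the series, on what has been measured and on what is new or still open speak of the compounds shown alone.

Measured compounds:
compound 1 `Cc1ccc(/C=C/C[C@H]2C[C@@H]([C@@H](O)c3ccccc3)CO[C@@H]2c2ccccc2)cc1C` gives 9880 nM
compound 2 `O[C@@H](c1ccccc1)[C@H]1CO[C@H](c2ccccc2)[C@@H](C/C=C/c2ccc(F)cc2)C1` gives 8110 nM

Both compounds were tested in a functional assay on HL-60 cells (Homo sapiens) for cytotoxicity, read by WST assay, with a stated time of 48 h; a lower number here means a stronger inhibitor, a higher number a weaker inhibitor. Going by the values given here, compound 1 and compound 2 share one core and differ only in the aryl group at the end of the side chain; the step of a 1.2-fold lower number from compound 1 to compound 2 (0.09 log units; within the scatter) lies within the scatter, so the two numbers cannot be told apart, and compound 1 stands level with its one neighbour.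

Compound 3 `Oc1ccccc1/C=C/C[C@H]1C[C@@H]([C@@H](O)c2ccccc2)CO[C@@H]1c1ccccc1` is the next variation on this theme. It differs from compound 1 as follows: 2-hydroxyphenyl in place of 3,4-dimethylphenyl on a double-bonded chain carbon bound to a double-bonded chain carbon

Among the compounds with values here, the only measured step that bears on this change is the one from compound 1 to compound 2, which was within the scatter. Within the data shown here, that step exchanged one aryl group for another without a hydroxyl; no measured pair shows what a hydroxyl in this place does, so the step to compound 3 in this assay is expected to be small, with no clear direction beyond the scatter, and the uncertainty is correspondingly wide.

For compound 3 the estimate is 8500 nM (range 3000 nM to 25000 nM), which corresponds to an expected step of a 1.2-fold lower number from compound 1 to compound 3 (0.07 log units; within the scatter).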

Compound 3, half-maximal inhibitory concentration: 10800 nM
The estimate for compound 3 lay 1.3-fold (0.10 log units) below the measured number; low and high end bracket the measured number.
By their numbers in this assay, from the lowest: compounds 2, 1 and 3 (each within the scatter of the next).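

In this assay, putting 2-hydroxyphenyl in place of 3,4-dimethylphenyl gives a 1.1-fold higher number from compound 1 to compound 3 (0.04 log units; within the scatter) and remains a small change, while putting it in place of 4-fluorophenyl gives a 1.3-fold higher number from compound 2 to compound 3 (0.12 log units; within the scatter) and is also small. Compound 3 is the first of these compounds whose aryl group carries a hydrogen-bond donor and a hydrogen-bond acceptor, yet its number cannot be told apart from those of the two compounds without them, so adding these features at this place on the side chain brings no readable change in this cell assay. No separate measurement is available to explain why the three numbers stay together.

The three aryl groups shown therefore mark no direction for improving the compounds, and a single hydroxyl in one ring position says little about whether 4-hydroxyphenyl, a methoxy group or a second hydroxyl would behave in the same way. Also open, from the compounds shown here alone, is whether a larger change at this end of the side chain, such as an amine, a carboxylic acid or a longer chain, would move the number beyond the scatter.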